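Swapping phenyl for 3,5-difluorophenyl on a sulfonyl sulfur

This account rests on a few compounds, and the source may have more. Where it says the series, first, only, none or still open, it means among the compounds named here.

Two compounds have been run through an ADME assay on microsomes from liver (Mus musculus) for metabolic stability, read by LC-MS, with a stated time of 30 min, tested at 1 uM (on this read-out lower numbers stand for a less stable compound and higher numbers for a more stable compound), so far. Compound 1 `O=C(NCc1ccc(S(=O)(=O)c2cc(F)cc(F)c2)cc1)c1cc2ccncc2o1` gives 12% in this assay. Compound 2 `O=C(NCc1ccc(S(=O)(=O)c2ccccc2)cc1)c1cnc2nccn2c1` gives 30% in this assay, the higher of the two numbers, and the gap between compound 1 and compound 2 lies beyond the usual scatter of such measurements. Compound 3 `O=C(NCc1ccc(S(=O)(=O)c2cc(F)cc(F)c2)cc1)c1cnc2nccn2c1` has not yet been measured. It keeps the core of compound 2 and differs from it in one place: 3,5-difluorophenyl in place of phenyl on a sulfonyl sulfur. Within the data shown here, no measured pair shows this change on its own, so the direction is uncertain. Compound 1 carries the same 3,5-difluorophenyl group with a different core and sits low, which gives a loose reason to expect compound 3 not to rise. For compound 3 the expected step is a number 3 percentage points lower from compound 2 to compound 3 (within the scatter), likely within the scatter, and its estimated value in this assay is 27%, with a range from 12% to 48%.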

Compound 3, percent of the compound remaining: 71%
For compound 3 the middle estimate is 44 percentage points below the measured one; the measured number lies above the stated range.
By their numbers in this assay, from the lowest: compound 1; then compound 2; then compound 3.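

In this assay the group on the sulfonyl sulfur turns out to matter a great deal: 3,5-difluorophenyl in place of phenyl, on an otherwise unchanged compound, brings a number 41 percentage points higher from compound 2 to compound 3 (beyond the scatter) on the shared core. The 3,5-difluorophenyl group does not give a high number by itself, since changing only the group on the carbonyl carbon brings a number 59 percentage points higher from compound 1 to compound 3 (beyond the scatter) and so the core counts as well. Nothing available here explains either step.

Still open, as far as these compounds go, is whether the same swap would raise the number on the core of compound 1, which would need that core with plain phenyl on the sulfonyl sulfur. Also open, from the compounds shown here alone, is how a phenyl ring carrying one fluorine, a chlorine or a methyl group would compare with 3,5-difluorophenyl.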